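The compounds below may be only part of what the source reports. "The series", "measured", "known", "first", "only" and "open" are said of these compounds alone.

Of the compounds shown here, three have been measured in a functional assay on the whole organism with Rattus norvegicus as the target; on this read-out higher numbers stand for an effect only at larger amounts of compound and lower numbers for an effect already at smaller amounts: compound 1 `Cc1ccccc1OCC(O)CNCC(=O)Nc1ccc(C2=NNC(=O)CC2)cc1` gives 2 umol/kg; compound 2 `Cc1ccccc1OCC(O)CNCC(=O)Nc1ccc(C2=NNC(=O)CC2C)cc1` gives 2.7 umol/kg; compound 3 `COc1ccccc1OCC(O)CNCCC(=O)Nc1ccc(C2=NNC(=O)CC2)cc1` gives 4.3 umol/kg.

Compound 2 differs from compound 1 by methyl in place of hydrogen on a saturated ring carbon, and this change brought a 1.4-fold higher number from compound 1 to compound 2 (0.13 log units; within the scatter). Compound 3 has a different core from compound 1; the difference between the two cores is not broken down here. Compound 4 `COc1ccccc1OCC(O)CNCCC(=O)Nc1ccc(C2=NNC(=O)CC2C)cc1` is drawn from compound 3 by methyl in place of hydrogen on a saturated ring carbon, the same change as that made from compound 1 to compound 2. Because the earlier step was a 1.4-fold higher number from compound 1 to compound 2 (0.13 log units; within the scatter), the same change on compound 3 is expected to give a step of about a 1.3-fold higher number from compound 3 to compound 4 (0.11 log units; within the scatter) in this assay. Compound 4 is therefore estimated at 5.5 umol/kg, with a likely range from 3 umol/kg to 11 umol/kg.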

Compound 4, dose for half-maximal effect: 3 umol/kg
For compound 4 the middle estimate is 1.8-fold (0.26 log units) above the measured one, and the stated range covers the measured number.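

In this assay methyl in place of hydrogen on a saturated ring carbon gives a 1.4-fold lower number from compound 3 to compound 4 (0.16 log units; within the scatter) on the core of compound 3. The two steps run in opposite directions, but neither step nor the gap between them lies beyond the scatter: the same change on two cores in this assay, a 1.4-fold higher number (0.13 log units; within the scatter) from compound 1 to compound 2 and a 1.4-fold lower number (0.16 log units; within the scatter) from compound 3 to compound 4, 1.9-fold (0.29 log units) apart, within the scatter of two such steps. This shows that the change carried between these two cores with no difference that can be told from the scatter, but it does not show that the two cores respond alike, or that the same would hold on any other core.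

The compounds shown leave open whether an ethyl or a hydroxyl group on that ring carbon would behave as methyl does. They also leave open what the methoxy group and the longer chain of compound 3 each contribute alone.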